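Working notes: cytotoxicity of three esters, compound 4 pending

The compounds below may be only part of what the source reports. "The series", "measured", "known", "first", "only" and "open" are said of these compounds alone.

Measured in an ADME assay on cells (T-cell, Mus musculus, strain BALB/c) for cytotoxicity, read by MTT assay, with a stated time of 48 h; on this read-out lower numbers stand for higher toxicity in this test and higher numbers for lower toxicity in this test:
compound 1 `COC(=O)c1ccc(Cl)cc1OC(=O)COc1cc(O)c2c(=O)cc(-c3ccccc3)oc2c1`: 265000 nM
compound 2 `COC(=O)c1c(Br)cccc1OC(=O)COc1cc(O)c2c(=O)cc(-c3ccccc3)oc2c1`: 388000 nM
compound 3 `COC(=O)c1c(C)cccc1OC(=O)COc1cc(O)c2c(=O)cc(-c3ccccc3)oc2c1`: 298000 nM

Compound 3 stands second highest of the three numbers; its nearest neighbour is compound 1, at a 1.1-fold higher number from compound 1 to compound 3 (0.05 log units; within the scatter), and its furthest is compound 2, at a 1.3-fold lower number from compound 2 to compound 3 (0.11 log units; within the scatter). Compound 4 `COC(=O)c1cc(Br)ccc1OC(=O)COc1cc(O)c2c(=O)cc(-c3ccccc3)oc2c1` differs from compound 3 by a group of 11 heavy atoms (8 carbon, 2 oxygen, 1 bromine; one six-membered aromatic ring of carbon only) in place of a group of 11 heavy atoms (9 carbon, 2 oxygen; one six-membered aromatic ring of carbon only), on an oxygen next to a carbonyl group. Within the data shown here, the steps that bear on this are the halogen swap a 1.5-fold higher number from compound 1 to compound 2 (0.17 log units; within the scatter) and the two steps that replace a halogen with methyl, all within the scatter. No step beyond the scatter is therefore expected in this assay, so compound 4 is estimated at 320000 nM (range 200000 nM to 520000 nM), a step of a 1.1-fold higher number from compound 3 to compound 4 (0.03 log units; within the scatter).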

Compound 4, half-maximal cytotoxic concentration: > 450000 nM
Compound 4: a limit, no number; the forecaster's own chance of this, stated with the estimate: 10%; at least 1.4-fold (0.14 log units) between middle value and limit.
By their numbers in this assay, from the lowest: compounds 1, 3 and 2 (each within the scatter of the next). At a limit, above all of these: compound 4.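

Unlike compound 1, compound 2 and compound 3, which give numbers, the 4-bromo-2-(methoxycarbonyl)phenyl group on this oxygen gives only a limit of the assay: the limit of > 450000 nM in this assay, at which 1 of the 4 values shown sits. The readable steps are floors only: an at least 1.5-fold higher number from compound 3 to compound 4 (0.17 log units; that floor lies within the scatter), an at least 1.1-fold higher number from compound 2 to compound 4 (0.06 log units; that floor lies within the scatter) and an at least 1.6-fold higher number from compound 1 to compound 4 (0.22 log units; that floor lies within the scatter). Each floor lies within the scatter, so this change is not yet shown to exceed it, though its size has no upper bound.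

Going by these compounds, whether compound 4 truly separates from the others stays open. So does how an amine or a carboxylic acid in place of the bromine would read.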